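This account rests on a few compounds, and the source may have more. Where it says the series, first, only, none or still open, it means among the compounds named here.

Three compounds of the series have numbers in an assay on HEK293 cells for inhibition of Steryl-sulfatase (Homo sapiens), tested at 0.1 uM; on this read-out lower numbers stand for a weaker effect and higher numbers for a stronger effect at the one concentration tested. Compound 1 `CN(C)CCN(CCN(C)C)c1ccc(C(=O)N2CCc3ccc(OS(N)(=O)=O)cc3C2)cc1` gives 3.8%, compound 2 `CCN(Cc1cccnc1)c1ccc(C(=O)N2CCc3ccc(OS(N)(=O)=O)cc3C2)cc1` gives 35.7%, and compound 3 `CCN(Cc1ccc(F)cc1)c1ccc(C(=O)N2CCc3ccc(OS(N)(=O)=O)cc3C2)cc1` gives 69.1%. Compound 3 stands highest of the three, and both steps up to it, a number 65.3 percentage points higher from compound 1 to compound 3 (beyond the scatter) and a number 33.4 percentage points higher from compound 2 to compound 3 (beyond the scatter), lie well beyond the scatter; the step of a number 31.9 percentage points higher from compound 1 to compound 2 (beyond the scatter) is also large.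

Compound 4 `CCN(Cc1ccccc1)c1ccc(C(=O)N2CCc3ccc(OS(N)(=O)=O)cc3C2)cc1` is the next member and differs from compound 3 only by hydrogen in place of fluoro on an aromatic carbon. Among the measured compounds shown here, no measured step removes a single fluoro; the only step that touches this part of the molecule, a number 33.4 percentage points higher from compound 2 to compound 3 (beyond the scatter), exchanges the whole ring and is therefore of limited use for a one-atom change. For the measured compounds named here, with the shared core, the amide and the ethylamino group all kept, no step beyond the scatter is expected in this assay, with a slight lean downward because the only measured change at this ring, a number 33.4 percentage points higher from compound 2 to compound 3 (beyond the scatter), raised the number. Compound 4 is expected to give about 60%, between 40% and 78%. The step of a number 9.1 percentage points lower from compound 3 to compound 4 (within the scatter) is thus estimated to stay within the scatter.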

Compound 4, a percentage reported as inhibition, at one concentration (the size of the read-out at that concentration, not a potency): 66.9%
Beside the measured number, compound 4's estimate is 6.9 percentage points below it; the range from low to high includes it.
By their numbers in this assay, from the lowest: compound 1; then compound 2; then compounds 4 and 3 (each within the scatter of the next).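

In this assay, the fluoro on the aromatic carbon para to a large group can give way to hydrogen with no difference beyond the scatter, a number 2.2 percentage points lower from compound 3 to compound 4 (within the scatter). The gain over the pyridin-3-yl compound therefore persists without the fluoro, with phenyl in place of pyridin-3-yl giving a number 31.2 percentage points higher from compound 2 to compound 4 (beyond the scatter), and benzyl(ethyl)amino in place of bis(2-(dimethylamino)ethyl)amino gives a number 63.1 percentage points higher from compound 1 to compound 4 (beyond the scatter). No measurement at hand accounts for these steps.

The compounds shown leave open whether methoxy, an amine or a carboxylic acid at this place on the phenyl ring would keep the number in this assay. They also leave open whether a propyl chain in place of the ethyl on the nitrogen would do so.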